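The compounds below may be only part of what the source reports. "The series", "measured", "known", "first", "only" and "open" are said of these compounds alone.

In a functional assay on HCT-15 cells (Homo sapiens) for cytotoxicity, read by ELISA, with a stated time of 4 days (on this read-out lower numbers stand for stronger inhibition and higher numbers for weaker inhibition), compound 1 (`Clc1ccc(-c2cc(-c3ccco3)cc(-c3ccc(Cl)s3)n2)cc1`) gives 1080 nM and compound 2 (`Cc1cccc(-c2cc(-c3ccoc3)cc(-c3ccc(Cl)s3)n2)c1`) gives 880 nM. These two numbers lie within the usual scatter of each other, so compound 2 stands level with compound 1. Compound 3 (`Clc1ccc(-c2cc(-c3ccoc3)cc(-c3cccnc3)n2)s1`) differs from compound 2 by having pyridin-3-yl in place of 3-methylphenyl on an aromatic carbon. Within the data shown here, no measured pair shows the effect of such a swap, so only a small move towards weaker inhibition is expected, within the scatter or close to it. The expected change is a 1.6-fold higher number from compound 2 to compound 3 (0.20 log units; within the scatter). The estimate for compound 3 is 1400 nM, with a range of 450 nM to 4500 nM.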

Compound 3, half-maximal inhibitory concentration: 720 nM
Estimate against measurement, compound 3: 1.9-fold (0.29 log units) above, and the stated range covers the measured number.
By their numbers in this assay, from the lowest: compounds 3, 2 and 1 (each within the scatter of the next).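

In this assay, the place next to the ring nitrogen accepts pyridin-3-yl in place of 3-methylphenyl with a 1.2-fold lower number from compound 2 to compound 3 (0.09 log units; within the scatter), so the two compounds stand level. This aromatic ring can therefore carry a ring nitrogen, counted as a hydrogen-bond acceptor, without a step beyond the scatter. Nothing measured here offers an explanation for this result. From the compounds shown here alone, whether an amine, a carboxylic acid or a longer chain at this place would also leave the number level remains open. So does whether pyridin-2-yl or pyridin-4-yl would match pyridin-3-yl.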